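Aryl swap on the shared core: compound 1 to compound 4

The compounds below may be only part of what the source reports. "The series", "measured", "known", "first", "only" and "open" are said of these compounds alone.

Measured so far, all in a functional assay on NCI-H1581 cells (Homo sapiens) for inhibition, read by MTT assay, with a stated time of 48 h, tested at 10 uM; on this read-out higher numbers stand for more inhibition at the one concentration tested (going by the name of the read-out) and lower numbers for less inhibition:
- compound 1 `COc1cc(Br)ccc1Nc1cc(NC(=O)Nc2c(Cl)cccc2Cl)ncn1`: 47.3%
- compound 2 `CCc1cccc(Nc2cc(NC(=O)Nc3cc(OC)cc(OC)c3)ncn2)c1`: 27.7%
- compound 3 `COc1cc(Nc2cc(NC(=O)Nc3c(Cl)cccc3Cl)ncn2)cc(OC)c1`: 68%

Compound 1 holds the second highest of the three numbers in this assay. Its nearest neighbour is compound 2, which sits lower by more than the usual scatter, and the furthest is compound 3, which sits higher by more than the scatter. No two of these three compounds differ in a single place, so none of the gaps can be read as a clean step.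

Compound 4 `O=C(Nc1cc(Nc2ccc(F)c(Cl)c2)ncn1)Nc1c(Cl)cccc1Cl` is not yet measured. It differs from compound 1 as follows: 3-chloro-4-fluorophenyl in place of 4-bromo-2-methoxyphenyl on a nitrogen on an aromatic ring. The rest of the molecule, including the urea and the shared core, is unchanged.

Within the data shown here, there is no measured step of this kind, and the three numbers in hand do not isolate what an aryl exchange at this nitrogen does. The expectation for the step of a number 2.3 percentage points lower from compound 1 to compound 4 (within the scatter) is therefore no change beyond the scatter, in either direction. Compound 4 is accordingly estimated at 45%, with a range from 25% to 65% in this assay, the width reflecting how little the available numbers constrain it.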

Compound 4, a percentage reported as inhibition, at one concentration (the size of the read-out at that concentration, not a potency): 67%
Beside the measured number, compound 4's estimate is 22 percentage points below it, outside the stated range (above it).
By their numbers in this assay, from the lowest: compound 2; then compound 1; then compounds 4 and 3 (each within the scatter of the next).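

In this assay, among these compounds, 3-chloro-4-fluorophenyl in place of 4-bromo-2-methoxyphenyl on a nitrogen on an aromatic ring gives a number 19.7 percentage points higher from compound 1 to compound 4 (beyond the scatter), the first single-place change in this set and the first direct sign that the aryl group at this position alters the read-out. Compound 4 at 67% and compound 3 at 68% lie within the scatter of each other, so with the same urea side, two different aryl groups at this position reach a similar number. No evidence at hand bears on the reason for the step.

The exchange removes the bromine and the methoxy group and brings in the chlorine and the fluorine all at once, so the compounds shown do not tell which of these changes carries the step, or whether it takes more than one. Also open, from the compounds shown here alone, is how the series would read with a morpholine, a piperazine or a carboxylic acid on this aryl group, and whether the single-concentration differences would hold up as differences in potency.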